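Chloro for methyl on the aryl ring of compound 3

A few compounds are considered here, and "the series" means these few. Any claim that something is new, unique, unknown or untested is made for them only; others in the source may bear on it.

Compound 3 `COC(=O)C1(c2ccc(C)cc2)CC1CN1CCN(c2ccccn2)CC1` gives 497 nM in an assay for displacement of a labelled ligand from Sigma non-opioid intracellular receptor 1 (Cavia porcellus) (on this read-out lower numbers stand for stronger inhibition and higher numbers for weaker inhibition), the highest number of the three in hand, though its gap to the nearest one lies within the scatter. That neighbour is compound 1 `COC(=O)C1(c2ccc(C)cc2)CC1CN1CCN(c2ncccn2)CC1`, which gives 353 nM; the step of a 1.4-fold higher number from compound 1 to compound 3 (0.15 log units; within the scatter) is within the scatter, so the two are not told apart by this read-out. Among the compounds with values here, the remaining measured compound, compound 2 `COC(=O)C1(c2ccc(C)cc2)CC1CN1CCC(Cc2ccccc2)CC1`, gives 0.97 nM, a number far below that of compound 3 and well beyond the scatter; no single-point step is given for that pair.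

Compound 4 `COC(=O)C1(c2ccc(Cl)cc2)CC1CN1CCN(c2ccccn2)CC1` differs from compound 3 by chloro in place of methyl on an aromatic carbon. Within the data shown here, the only measured step in the set, a 1.4-fold higher number from compound 1 to compound 3 (0.15 log units; within the scatter), concerns the group on an amine nitrogen in a ring, not the aromatic carbon touched here, so it does not bear on this change directly, and no measured pair shows chloro in place of methyl. With nothing in the data pointing either way, the step is expected to stay within the scatter. Compound 4 is therefore estimated at 500 nM, with a range of 150 nM to 1600 nM; the implied step, a 1.0-fold higher number from compound 3 to compound 4 (0.00 log units; within the scatter), is expected to be within the scatter.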

Compound 4, inhibition constant: 707 nM
Compound 4: the middle estimate sits 1.4-fold (0.15 log units) below what was measured; low and high end bracket the measured number.
By their numbers in this assay, from the lowest: compound 2; then compounds 1, 3 and 4 (each within the scatter of the next).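

Within the data shown here, at the aromatic carbon para to a large group, the change from 4-methylphenyl to 4-chlorophenyl gives the first reading for this position in this assay (a 1.4-fold higher number from compound 3 to compound 4 (0.15 log units; within the scatter)), and this read-out does not tell compound 3 and compound 4 apart. The series now has two steps that each differ in one place, one on the aryl ring and one on the amine nitrogen in a ring (a 1.4-fold higher number from compound 1 to compound 3 (0.15 log units; within the scatter)), and both lie within the scatter, so neither separates its pair on this read-out. No supporting measurement accompanies these compounds that could account for the chloro and methyl pair reading alike.

As far as these compounds go, whether a group of another kind on this aromatic carbon, such as a methoxy, a carboxylic acid or an amine, would give a step beyond the scatter remains open. Also open, from the compounds shown here alone, is whether chloro in place of methyl reads the same in the setting of compound 2, which stands at 0.97 nM, since a step on that aryl ring is available only for the pair of compound 3 and compound 4.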